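The source may report more compounds than this note shows. Statements on the series, on what has been measured and on what is new or still open speak of the compounds shown alone.

Measured compounds:
compound 1 `c1ccc(-c2nnc(-c3c[nH]c4ccccc34)o2)cc1`, > 1000000 nM
compound 2 `COc1cc(-c2nnc(-c3cn(C)c4ccccc34)o2)ccc1OCc1ccccc1`, > 1000000 nM

Both measured compounds were tested in a functional assay on MDA-MB-231 cells (Homo sapiens) for cytotoxicity, read by MTT assay; a higher number here means a weaker inhibitor, a lower number a stronger inhibitor. In this assay compound 1 gives > 1000000 nM, which is a limit of the assay rather than a number. Compound 2 gives > 1000000 nM, likewise a limit. Compound 1 therefore stands at the limit of > 1000000 nM in this assay, at which 2 of the 2 values shown sit, and no numbered value is available to place it against. Compound 3 `Cc1nnc(-c2c[nH]c3ccccc23)o1` shares the core of compound 1 and differs from it by methyl in place of phenyl on an aromatic carbon. No step between two measured compounds exists here, so nothing shown indicates how far this change could move the result in either direction. Because compound 1 sits at the limit of > 1000000 nM in this assay, at which 2 of the 2 values shown sit, compound 3 is expected to remain at or near the limit of this assay as well, with an expected step that the limit leaves unreadable from compound 1 to compound 3. The estimate for compound 3 is 1500000 nM, within 300000 nM to 10000000 nM.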

Compound 3, half-maximal inhibitory concentration: > 1000000 nM
Compound 3 was reported as a limit; the forecaster's own chance of this, stated with the estimate: 85%; the middle value lies beyond the limit too.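

Compound 3, like compound 1, is reported in this assay only as a limit, so no step can be read for methyl in place of phenyl between these two compounds. The compounds shown leave open how far this change moves the result, and the only reading they share is a limit: the limit of > 1000000 nM in this assay, at which 3 of the 3 values shown sit.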